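Shortening the urea alkyl chain on a cyanoaziridine

The source may report more compounds than this note shows. Statements on the series, on what has been measured and on what is new or still open speak of the compounds shown alone.

Measured compounds:
- compound 1, `CCOC(=O)c1ccc(NC(=O)N2CC2C#N)cc1`: 3000 nM
- compound 2, `CCCCNC(=O)N1CC1C#N`: 17000 nM
- compound 3, `N#CC1CN1C(=O)Nc1cccnc1`: 12000 nM

In a functional assay on RPMI-8226 cells (Homo sapiens) for inhibition (on this read-out lower numbers stand for stronger inhibition and higher numbers for weaker inhibition), compound 2 gives 17000 nM, the highest number of the three. Compound 3 gives 12000 nM, a value within the scatter of compound 2, so no order between the two can be read. Compound 1 gives 3000 nM, a gap beyond the scatter. Compound 4, `CNC(=O)N1CC1C#N`, is not yet measured; it differs from compound 2 in one place: hydrogen in place of propyl on a saturated chain carbon bound to an amide-type nitrogen. Going by the values given here, no step between measured compounds isolates this kind of change, so the size of the step in this assay is uncertain; a small rise in the number, or none beyond the scatter, is expected. For compound 4 the estimated value is 25000 nM, with a range from 8000 nM to 80000 nM, meaning an expected step of a 1.5-fold higher number from compound 2 to compound 4 (0.17 log units; within the scatter).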

Compound 4, half-maximal inhibitory concentration: 26000 nM
Estimate against measurement, compound 4: 1.0-fold (0.02 log units) below; low and high end bracket the measured number.
By their numbers in this assay, from the lowest: compound 1; then compounds 3, 2 and 4 (each within the scatter of the next, the first and the last beyond it).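

Going by these compounds alone, this is the first step here that isolates a single change. In this assay, going from butyl to methyl gives a 1.5-fold higher number from compound 2 to compound 4 (0.18 log units; within the scatter), so at this position, losing propyl on a saturated chain carbon bound to an amide-type nitrogen moves the number by no more than repeat measurements would. No measurement shown gives a reason for this result.

From the compounds shown here alone, whether a longer chain, such as octyl, or a chain carrying an amine or a carboxylic acid would move the number beyond the scatter remains open. One step also cannot show whether the same swap would behave alike on another core.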